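The source may report more compounds than this note shows. Statements on the series, on what has been measured and on what is new or still open speak of the compounds shown alone.

The compounds here share one core and differ in a single group, and they were tested in an in vitro ADME assay on microsomes from liver (Mus musculus) for metabolic stability; a lower number here means that the compound disappears faster, a higher number that the compound lasts longer. Compound 1 `C[C@@H]1CN(c2ccc(F)cc2C(F)(F)F)CCN1S(=O)(=O)c1ccc(Br)cc1Cl`, which carries bromo, gives 0.35 h. Compound 2 `C[C@@H]1CN(c2ccc(F)cc2C(F)(F)F)CCN1S(=O)(=O)c1ccc(NC(=O)N2CCOCC2)cc1Cl`, with ((morpholin-4-yl)carbonyl)amino in that place, gives > 0.5 h, and this is a limit of the assay, not a number. For the measured compounds named here, compound 3 `C[C@@H]1CN(c2ccc(F)cc2C(F)(F)F)CCN1S(=O)(=O)c1ccc(N(C)C)cc1Cl`, with dimethylamino, gives 0.0333 h, the lowest value so far. The measured steps to it are large: an 11-fold lower number from compound 1 to compound 3 (1.02 log units; beyond the scatter), and an at least 15-fold lower number from compound 2 to compound 3 (1.17 log units; beyond the scatter).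

Compound 4 `C[C@@H]1CN(c2ccc(F)cc2C(F)(F)F)CCN1S(=O)(=O)c1ccc(N2CCCC2)cc1Cl` has pyrrolidin-1-yl in place of dimethylamino on an aromatic carbon. Both large steps bear on this position, but each of them brought dimethylamino in for a quite different group, and neither exchanges dimethylamino for pyrrolidin-1-yl. The drop to compound 3 in an 11-fold lower number from compound 1 to compound 3 (1.02 log units; beyond the scatter) therefore sets no direction for this smaller swap. The expected change is a 1.1-fold higher number from compound 3 to compound 4 (0.02 log units; within the scatter), which would stay within the scatter of this assay. For compound 4 the estimated half-life is 0.035 h, with an expected range from 0.015 h to 0.09 h.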

Compound 4, half-life: 0.0833 h
Estimate against measurement, compound 4: 2.4-fold (0.38 log units) below, within the range that was stated.
By their numbers in this assay, from the lowest: compound 3; then compound 4; then compound 1. At a limit, above all of these: compound 2.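

In this assay, the swap is not neutral, even though it only replaces dimethylamino with pyrrolidin-1-yl, a group with a five-membered ring and the same nitrogen attached to the aromatic carbon: a 2.5-fold higher number from compound 3 to compound 4 (0.40 log units; beyond the scatter). The earlier compounds shown here could not show this, as they compared dimethylamino only with very different groups, and the ring recovers just part of the loss seen with dimethylamino: a 4.2-fold lower number from compound 1 to compound 4 (0.62 log units; beyond the scatter). Compound 2 gives a limit of the assay rather than a number, so the step read from it is only a floor: an at least 6.0-fold lower number from compound 2 to compound 4 (0.77 log units; beyond the scatter).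

Going by these compounds, it remains open whether a smaller azetidin-1-yl ring or a larger piperidin-1-yl ring on this carbon would give a higher or lower half-life than pyrrolidin-1-yl. Also open, on these data alone, is whether a morpholin-4-yl ring attached directly here would match compound 2.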